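The compounds below may be only part of what the source reports. "The series", "measured", "known", "first", "only" and "open" are said of these compounds alone.

Compound 1 `O=C(O)c1cn(C2CC2)c2c(F)c(N3CCNCC3)c(F)cc2c1=O`: 47 ug/mL
Compound 2 `O=C(O)c1cn(C2CC2)c2c(C(F)(F)F)c(N3CCNCC3)c(F)cc2c1=O`: 1650 ug/mL
Compound 3 `NC1CCN(c2c(F)c(F)c3c(=O)c(C(=O)O)cn(C4CC4)c3c2F)C1`: 100 ug/mL

These three compounds were tested in a functional assay on V79 cells (Cricetulus griseus) for cytotoxicity, read by colony formation; on this read-out higher numbers stand for weaker inhibition and lower numbers for stronger inhibition. Compound 2 differs from compound 1 by trifluoromethyl in place of fluoro on an aromatic carbon, and this change gave a 35-fold higher number from compound 1 to compound 2 (1.55 log units; beyond the scatter). How the core of compound 1 differs from the core of compound 3 is not broken down here; their values simply stand as given.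

Compound 4, `NC1CCN(c2c(F)c(F)c3c(=O)c(C(=O)O)cn(C4CC4)c3c2C(F)(F)F)C1`, has not yet been measured. It differs from compound 3 by trifluoromethyl in place of fluoro on an aromatic carbon. For the measured compounds named here, this is the same kind of change as the one from compound 1 to compound 2, though not the same: in compound 1 the carbon that changes is ortho to a piperazin-1-yl group, whereas in compound 3 it is ortho to a 3-aminopyrrolidin-1-yl group and para to a fluoro group. Because the same kind of change produced a 35-fold higher number from compound 1 to compound 2 (1.55 log units; beyond the scatter), a step of similar size is expected here, a 30-fold higher number from compound 3 to compound 4 (1.48 log units; beyond the scatter). Compound 4 is therefore estimated at 3000 ug/mL in this assay, with an expected range from 700 ug/mL to 10000 ug/mL.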

Compound 4, half-maximal inhibitory concentration: 190 ug/mL
For compound 4 the middle estimate is 16-fold (1.20 log units) above the measured one; measured number outside the range, below it.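

In this assay, trifluoromethyl in place of fluoro gave a 1.9-fold higher number from compound 3 to compound 4 (0.28 log units; within the scatter), so the large step seen on the core of compound 1 did not carry over to the core of compound 3. Set side by side, the two results differ: the same change on two cores in this assay, a 35-fold higher number (1.55 log units; beyond the scatter) from compound 1 to compound 2 and a 1.9-fold higher number (0.28 log units; within the scatter) from compound 3 to compound 4, 18-fold (1.27 log units) apart, beyond the scatter of two such steps The size of this change thus depends on the core across these two pairs, but the pairs do not show which difference between the cores matters, the piperazin-1-yl group against the 3-aminopyrrolidin-1-yl group or the fluoro group para to the changing carbon, and they predict nothing for a third core.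

The compounds shown leave open whether the large step belongs to the piperazin-1-yl group itself or needs the rest of the core of compound 1. They also leave open how the same carbon would respond to other replacements for fluoro, such as chlorine, a methyl group or a nitrile.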